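A Nitrile in Place of the Sulfonamide Group

This account rests on a few compounds, and the source may have more. Where it says the series, first, only, none or still open, it means among the compounds named here.

Compound 1, `O=C(NCc1ccc(F)cc1)c1cccc(O)c1O`, in an ADME assay on NCI-H630 cells (Homo sapiens) for cytotoxicity, read by MTT assay, with a stated time of 72 h; a lower number here means that less compound is tolerated, a higher number that more compound is tolerated: > 40000 nM, which is a limit of the assay and not a number.
Compound 2, `CC(C)(C)NS(=O)(=O)c1cc(O)c(O)c(C(=O)NCc2ccc(F)cc2)c1`, in this assay: > 10000 nM, again a limit of the assay and not a number.

Compound 2 stands at the limit of > 10000 nM in this assay, at which 1 of the 2 values shown sits. Compound 1 stands at the limit of > 40000 nM in this assay, at which 1 of the 2 values shown sits. Among the measured compounds shown here, the single measured step, a step that the two limits leave unreadable from compound 1 to compound 2, has no readable size; the two limits do not allow any direction to be read from it.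

Compound 3, `N#Cc1cc(O)c(O)c(C(=O)NCc2ccc(F)cc2)c1`, differs from compound 2 by cyano in place of (tert-butyl)sulfamoyl on an aromatic carbon. For the measured compounds named here, no measured step bears on this change in a readable way: the only step in this assay is the unreadable one just described, and both measured compounds sit at a limit. The one thing the data show is that neither compound reached a measurable half-maximal cytotoxic concentration. Compound 3 is therefore expected to remain in that region, and the step that the limit leaves unreadable from compound 2 to compound 3 is expected to show nothing beyond the scatter. The estimate for compound 3 in this assay is 30000 nM, with a range from 8000 nM to 120000 nM, and most likely the assay will again report only a limit.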

Compound 3, half-maximal cytotoxic concentration: > 10000 nM
Compound 3 ended at the assay's limit; the forecaster's own chance of this, stated with the estimate: 80%; the middle value is on the limit's open side.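

Compound 3 also ended at a limit of the assay and not at a number: the limit of > 10000 nM in this assay, at which 2 of the 3 values shown sit.

Its steps from compound 1 and from compound 2 therefore cannot be read in this assay. The compounds shown leave open where the half-maximal cytotoxic concentration of each lies, and whether cyano or (tert-butyl)sulfamoyl in place of hydrogen shifts it at all.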